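A few compounds are considered here, and "the series" means these few. Any claim that something is new, unique, unknown or untested is made for them only; others in the source may bear on it.

Compound 1, `CN(C)CCCCCCOc1ccc2oc(-c3ccccc3)cc(=O)c2c1`, gives 335 nM.
Compound 2, `CN(C)CCCCCCCCCCOc1ccc2oc(-c3ccccc3)cc(=O)c2c1`, gives 341 nM.
Compound 3, `O=c1cc(-c2ccccc2)oc2ccc(OCCCCCCN3CCCC(O)C3)cc12`, gives 77 nM.

All three were tested in an assay on isolated protein (Cavia porcellus) with Sigma non-opioid intracellular receptor 1 (Homo sapiens) as the target, read by radioligand binding; a lower number here means a stronger inhibitor, a higher number a weaker inhibitor. Compound 3 has the lowest number of the three, and its steps from the other two are both beyond the scatter: a 4.4-fold lower number from compound 1 to compound 3 (0.64 log units; beyond the scatter) and a 4.4-fold lower number from compound 2 to compound 3 (0.65 log units; beyond the scatter). Between compound 1 and compound 2 nothing separates them: a 1.0-fold higher number from compound 1 to compound 2 (0.01 log units; within the scatter).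

Compound 4, `O=c1cc(-c2ccccc2)oc2ccc(OCCCCCCN3CCNC(CCO)C3)cc12`, has not yet been measured. It differs from compound 3 in one place: 3-(2-hydroxyethyl)piperazin-1-yl in place of 3-hydroxypiperidin-1-yl on a saturated chain carbon, six bonds along the chain from an oxygen on an aromatic ring. The two steps that bear on this are those that brought the 3-hydroxypiperidin-1-yl group in, each a modest gain. Compound 4 keeps a six-membered ring with a hydroxyl-bearing substituent at the same place on the chain, so a change of about that size at most is expected, in either direction, and most likely none beyond the scatter. For compound 4 in this assay the expected step is a 1.6-fold higher number from compound 3 to compound 4 (0.19 log units; within the scatter), giving an estimate of 120 nM with a range from 40 nM to 400 nM.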

Compound 4, half-maximal inhibitory concentration: 94 nM
Compound 4: the middle estimate sits 1.3-fold (0.11 log units) above what was measured; the measured number falls inside the stated range.
By their numbers in this assay, from the lowest: compounds 3 and 4 (each within the scatter of the next); then compounds 1 and 2 (each within the scatter of the next).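

In this assay, the step to the larger ring group, a six-membered ring with 2 hetero atoms in place of one with 1 hetero atom, stays small: a 1.2-fold higher number from compound 3 to compound 4 (0.09 log units; within the scatter). The gain over the simple amines also holds, with a 3.6-fold lower number from compound 1 to compound 4 (0.55 log units; beyond the scatter) and a 3.6-fold lower number from compound 2 to compound 4 (0.56 log units; beyond the scatter), so at this place on the chain it does not depend on the 3-hydroxypiperidin-1-yl group alone. No measurement available here says why these two ring groups give such similar numbers.

As far as these compounds go, what a plain piperidin-1-yl group, with no hydroxyl on the ring, would give at this place remains open, and so does a piperazin-1-yl group without the 2-hydroxyethyl arm. From the compounds shown here alone, it is also open whether either ring group would keep its number on the longer chain of compound 2.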